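Two Chlorinations of a Fused Core and Their Cost to Cells

The compounds below may be only part of what the source reports. "The series", "measured", "known", "first", "only" and "open" are said of these compounds alone.

The account concerns four compounds built on fused cores bearing a chloromethyl-substituted benzyl group. Compound 1 `ClCc1ccccc1Cn1cnc2c(Cl)nc(Cl)nc21` and compound 2 `ClCc1ccccc1Cn1cnc2c(Cl)ncnc21` share one core; compound 3 `ClCc1ccccc1Cn1cnc2ncnc(Cl)c21` and the unmeasured compound 4 `ClCc1ccccc1Cn1cnc2nc(Cl)nc(Cl)c21` share another. In a functional assay on SW-620 cells (Homo sapiens) for cytotoxicity, read by sulforhodamine B assay, with a stated time of 48 h (a lower number here means that less compound is tolerated, a higher number that more compound is tolerated), compound 1 gives 810 nM, compound 2 gives 26300 nM, and compound 3 gives 10000 nM. Within the data shown here, compounds 2 and 3 have the same atoms joined differently; the difference between the two cores is not broken down here, and the two values show only that compound 3 is tolerated less than compound 2.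

Within the first pair the step is a 32-fold lower number from compound 2 to compound 1 (1.51 log units; beyond the scatter), and the change is chloro in place of hydrogen on an aromatic carbon. From compound 3 to compound 4 the change is chloro in place of hydrogen on an aromatic carbon; the place lines agree word for word, so it is the same change, occurring twice among these compounds.

Among the measured compounds shown here, since the single measured instance of this change gave a large step beyond the scatter, compound 4 is expected to be tolerated much less than compound 3, at an estimated 400 nM, within 100 nM to 2000 nM, a step of a 25-fold lower number from compound 3 to compound 4 (1.40 log units; beyond the scatter). The expectation rests on one pair only, and the core of compound 3 differs from that of compound 2, so the width is kept generous.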

Compound 4, concentration lethal to 50% of the cells: 4670 nM
Beside the measured number, compound 4's estimate is 12-fold (1.07 log units) below it, outside the stated range (above it).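

In this assay, chloro in place of hydrogen on an aromatic carbon again lowers the number, with a 2.1-fold lower number from compound 3 to compound 4 (0.33 log units; beyond the scatter), so across the two pairs shown the change keeps its direction when it is carried from one core to the other. Among these compounds, the size of the step does not carry over, and the two instances of this one change differ clearly: the same change on two cores in this assay, a 32-fold lower number (1.51 log units; beyond the scatter) from compound 2 to compound 1 and a 2.1-fold lower number (0.33 log units; beyond the scatter) from compound 3 to compound 4, 15-fold (1.18 log units) apart, beyond the scatter of two such steps This shows that, in this series, a step measured on one core cannot be used as the size of the step on the other, but with only two pairs it gives no rule for any further core and does not show which feature of the cores, or of the place of the new chloro group on them, sets the two sizes apart.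

The compounds shown leave open whether another group on the aromatic carbon between two ring nitrogen atoms, such as an amine, a methoxy group or a fluoro group, would lower the number on both cores or on only one. They also leave open how much the chloromethyl group contributes to these numbers, a question that a compound carrying a plain methyl group in its place on each core could address.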